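Cytotoxicity outlook for a methoxymethyl analogue of compound 1

The source may report more compounds than this note shows. Statements on the series, on what has been measured and on what is new or still open speak of the compounds shown alone.

Compound 1 `COc1ccccc1-c1nc(/C=C/c2cc3ccccc3nc2OC)no1` — in an ADME assay on HepG2 cells (Homo sapiens) for cytotoxicity, read by sulforhodamine B assay, with a stated time of 48 h (a higher number here means that more compound is tolerated, a lower number that less compound is tolerated), compound 1 gives > 220000 nM, a limit of the assay, not a number.
Compound 2 `COc1nc2ccccc2cc1/C=C/c1noc(-c2cccc(C)c2)n1` — in this assay compound 2 gives > 230000 nM, again a limit.
Compound 3 `COc1nc2ccccc2cc1/C=C/c1noc(-c2cccc(Cl)c2)n1` — in this assay compound 3 gives > 220000 nM, again a limit.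

Compound 1 therefore stands at a limit, and so do the two compounds beside it. Among the compounds with values here, two of the three values sit at the limit of > 220000 nM in this assay, at which 2 of the 3 values shown sit, and one at the limit of > 230000 nM in this assay, at which 1 of the 3 values shown sits, so no compound can be placed above or below another. The steps a step that the two limits leave unreadable from compound 1 to compound 2, a step that the two limits leave unreadable from compound 1 to compound 3 and a step that the two limits leave unreadable from compound 2 to compound 3 are all unreadable for the same reason.

Compound 4 `COCc1nc(/C=C/c2cc3ccccc3nc2OC)no1` differs from compound 1 by methoxymethyl in place of 2-methoxyphenyl on an aromatic carbon. The measured steps only swap one ring-bearing group for another ring-bearing group on the same carbon; none removes the ring, so none speaks directly to this change. What they do show is that every variation tried there left the value at a limit. The expectation is thus no step beyond the scatter, a step that the limit leaves unreadable from compound 1 to compound 4. Compound 4 is estimated at 250000 nM, within 100000 nM to 600000 nM, most probably again reported as a limit.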

Compound 4, half-maximal cytotoxic concentration: > 270000 nM
Compound 4: a limit, no number; the forecaster's own chance of this, stated with the estimate: 80%; middle value at least 1.0-fold (0.03 log units) from the limit.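

In this assay compound 4 gives > 270000 nM, a limit of the assay and not a number. Its steps from compound 1, compound 2 and compound 3 cannot be read. The compounds shown leave open what actual half-maximal cytotoxic concentration any of the four has, and whether changing this group shifts it at all.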